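Swapping a Methyl for a Phenyl on an Amide

The source may report more compounds than this note shows. Statements on the series, on what has been measured and on what is new or still open speak of the compounds shown alone.

This set of compounds shares one core and differs at the group sitting on a carbonyl carbon next to an amide-type nitrogen. Compound 1 `O=C(NCc1ccccc1C(=O)N[C@H](/C=C/S(=O)(=O)c1ccccc1)CCc1ccccc1)c1cccc(O)c1` carries a 3-hydroxyphenyl there and gives 36000 nM in a toxicity assay on J774.1 cells (Mus musculus) for cytotoxicity, read by MTT assay, with a stated time of 48 h; a lower number here means that less compound is tolerated, a higher number that more compound is tolerated. Compound 2 `CC(=O)NCc1ccccc1C(=O)N[C@H](/C=C/S(=O)(=O)c1ccccc1)CCc1ccccc1` carries a methyl in the same position and gives 48000 nM. Compound 3 `O=C(NCc1ccccc1C(=O)N[C@H](/C=C(\F)S(=O)(=O)Oc1ccccc1)CCc1ccccc1)c1ccc2c(c1)OCCO2`, built with a different warhead and a dioxane-fused ring on the carbonyl, reaches only a limit: its result is > 100000 nM, which is a limit of the assay and not a number.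

Among the two numbers given, compound 2 stands highest, with compound 1 nearest. For the measured compounds named here, the step of a 1.3-fold higher number from compound 1 to compound 2 (0.12 log units; within the scatter) is the only measured change at this position, and it stays within the scatter.

Compound 4 `O=C(NCc1ccccc1C(=O)N[C@H](/C=C/S(=O)(=O)c1ccccc1)CCc1ccccc1)c1ccccc1` is the unmeasured relative: phenyl in place of methyl on a carbonyl carbon, or acetamidomethyl to benzamidomethyl. Going by the values given here, the closest precedent is the step from compound 1 to compound 2, which exchanged an aromatic ring for a methyl at this carbon without a change beyond the scatter. Going back from a methyl to an aromatic ring is therefore expected to move the number little. The expected step is a 1.2-fold lower number from compound 2 to compound 4 (0.08 log units; within the scatter), and for compound 4 the estimate is 40000 nM, within a range from 20000 nM to 80000 nM.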

Compound 4, half-maximal cytotoxic concentration: > 100000 nM
Compound 4 was reported as a limit; the forecaster's own chance of this, stated with the estimate: 10%; middle value at least 2.5-fold (0.39 log units) from the limit.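

In this assay compound 4 gives > 100000 nM, which is a limit of the assay and not a number: the limit of > 100000 nM in this assay, at which 2 of the 4 values shown sit.

The earlier compounds shown here suggested that this carbonyl carbon might not respond to its group, but placing phenyl there in place of methyl gives an at least 2.0-fold higher number from compound 2 to compound 4 (0.31 log units; beyond the scatter), so the group at this position can matter for how much compound the cells tolerate. The hydroxy matters too, since hydrogen in place of hydroxy on an aromatic carbon gives an at least 2.7-fold higher number from compound 1 to compound 4 (0.44 log units; beyond the scatter), which means that having an aromatic ring on this carbonyl carbon does not settle the number by itself, as compound 1 also carries one.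

From the compounds shown here alone, both steps are minimum sizes only, so how far compound 4 really lies from compound 1 and compound 2 remains unknown, and the reason for either step also stays open. Also open, going by these compounds, is what a longer chain in place of methyl on this carbonyl carbon would give, or a carboxylic acid or an amine in place of the hydroxy of compound 1.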